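A few compounds are considered here, and "the series" means these few. Any claim that something is new, unique, unknown or untested is made for them only; others in the source may bear on it.

In a functional assay on C8166 cells (Homo sapiens) for antiproliferative activity, read by MTT assay (a higher number here means that more compound is tolerated, a lower number that less compound is tolerated), compound 2 (`O=C(NN1CCOC1=O)c1[nH]c2ccc(Cl)cc2c1S(=O)(=O)c1ccccc1`) gives > 100 uM, which is a limit of the assay and not a number. Compound 3 (`Cc1cc(C)cc(S(=O)(=O)c2c(C(=O)NN3CCOC3=O)[nH]c3ccc(Cl)cc23)c1`) has 3,5-dimethylphenyl in place of phenyl on a sulfonyl sulfur. For the measured compounds named here, no measured pair shows this change. Compound 1 (`Cc1cc(C)cc(S(=O)(=O)c2c(C(=O)NCC(N)=O)[nH]c3ccc(Cl)cc23)c1`) also carries 3,5-dimethylphenyl and gives > 100 uM, again a limit. Its value supports an expectation of no step beyond the usual scatter, in either direction. The expected change is a number no higher from compound 2 to compound 3 (the limit leaves the size open). For compound 3 the estimated value is 100 uM, with an expected range from 40 uM to 200 uM.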

Compound 3, half-maximal toxic concentration: > 100 uM
Compound 3: a limit, no number (the forecaster's own chance of this, stated with the estimate: 70%); the middle value lies on the limit itself.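

For the compounds shown here, neither the step from compound 2 to compound 3 nor the one from compound 1 to compound 3 can be read, because all three compounds give a limit, not a number: the limit of > 100 uM in this assay, at which 3 of the 3 values shown sit. The compounds shown leave open the true toxic concentration of each, and so whether 3,5-dimethylphenyl in place of phenyl changes it at all.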